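The source may hold more compounds than are shown below. What is called first, only, known or untested is meant among the compounds shown, and "the series" means these compounds.

Measured compounds in an ADME assay on Huh-7 cells (Homo sapiens) for cytotoxicity; on this read-out lower numbers stand for higher toxicity in this test and higher numbers for lower toxicity in this test:
Compound 1 `O=C(NC(=S)N1CCc2c(OCc3ccccc3)cccc21)c1ccccc1`: compound 1 gives > 50000 nM, which is a limit of the test rather than a number.
Compound 2 `O=C(NC(=S)N1CCc2ccc(OCc3ccccc3)cc21)c1ccccc1`: compound 2 gives 43800 nM.
Compound 3 `O=C(NC(=S)N1CCc2c(OCCCCCOc3ccc(Cl)cc3)cccc21)c1ccc(Cl)cc1`: compound 3 gives 21700 nM.

Compound 3 stands lowest of the two numbers; its nearest neighbour, compound 2, sits at a two-step higher reading that lies beyond the usual scatter, and compound 1 reached only the limit of this assay.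

Compound 4 `O=C(NC(=S)N1CCc2c(OCCCCCOc3ccc(Cl)cc3)cccc21)c1ccc2ccccc2c1` differs from compound 3 in one place: naphthalen-2-yl in place of 4-chlorophenyl on a carbonyl carbon. Among the compounds with values here, no measured pair shows this change, so its effect in this assay is open. A small step is expected for compound 4, within or just past the scatter, with the direction unclear. Compound 4 is estimated at 18000 nM, between 7000 nM and 50000 nM, meaning an expected step of a 1.2-fold lower number from compound 3 to compound 4 (0.08 log units; within the scatter).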

Compound 4, half-maximal cytotoxic concentration: > 50000 nM
Compound 4: a limit, no number (the forecaster's own chance of this, stated with the estimate: 20%); at least 2.7-fold (0.44 log units) between middle value and limit.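

Placing naphthalen-2-yl instead of 4-chlorophenyl on the carbonyl carbon gives an at least 2.3-fold higher number from compound 3 to compound 4 (0.36 log units; beyond the scatter) in this assay. This first single-place comparison shows that the group on this carbonyl carbon can change the read-out, moving it towards lower toxicity in this test. The step is only a lower bound, and its full size cannot be read: the limit of > 50000 nM in this assay, at which 2 of the 4 values shown sit.

The compounds shown do not separate the loss of the chlorine from the gain of the second aromatic ring. They also leave open how a phenyl carrying an amine or a carboxylic acid would read here.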